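Chloro to Cyano on a Diaryl Thiourea Core

A few compounds are considered here, and "the series" means these few. Any claim that something is new, unique, unknown or untested is made for them only; others in the source may bear on it.

Measured compounds:
compound 1: `FC(F)(F)c1cccc(NC(=S)Nc2ccc(Cl)cc2)c1` — 11000 nM
compound 2: `O=[N+]([O-])c1ccc(NC(=S)Nc2cccc(C(F)(F)F)c2)cc1` — 8200 nM
compound 3: `Fc1ccc(NC(=S)Nc2cccc(C(F)(F)F)c2)cc1Cl` — 9500 nM

In a functional assay on CCRF-SB cells (Homo sapiens) for cytotoxicity, read by MTT assay, with a stated time of 96 h (on this read-out higher numbers stand for lower toxicity in this test and lower numbers for higher toxicity in this test), compound 1 gives the highest of the three numbers, but its neighbours sit close: compound 3 gives 9500 nM and compound 2 gives 8200 nM, both within the usual scatter of compound 1. For the measured compounds named here, the only single-point step measured so far is a 1.3-fold lower number from compound 1 to compound 2 (0.13 log units; within the scatter), a change of nitro in place of chloro on an aromatic carbon that left the read-out essentially unchanged. Going by the values given here, no step is recorded between compound 1 and compound 3; their two values simply lie close together.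

Compound 4 is `N#Cc1ccc(NC(=S)Nc2cccc(C(F)(F)F)c2)cc1`. It differs from compound 1 as follows: cyano in place of chloro on an aromatic carbon. This is the same position that was altered from compound 1 to compound 2, and that alteration stayed within the scatter. On that basis the account expects no step beyond the scatter for compound 4, in either direction, and puts the expected step at a 1.2-fold lower number from compound 1 to compound 4 (0.06 log units; within the scatter). Compound 4 is therefore estimated at 9500 nM in this assay, with a range from 4500 nM to 20000 nM.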

Compound 4, half-maximal cytotoxic concentration: 8300 nM
Compound 4: the middle estimate sits 1.1-fold (0.06 log units) above what was measured, within the range that was stated.
By their numbers in this assay, from the lowest: compounds 2, 4, 3 and 1 (each within the scatter of the next).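

In this assay, a second replacement of chloro on this aromatic carbon, para to a large group, gives a 1.3-fold lower number from compound 1 to compound 4 (0.12 log units; within the scatter), so the absence of a step beyond the scatter no longer rests on nitro alone. The two entering groups also cannot be told apart here: the direct comparison gives a 1.0-fold higher number from compound 2 to compound 4 (0.01 log units; within the scatter), and the change from nitro to cyano leaves the read-out where it was. Among chloro, nitro and cyano, this place has so far shown no sensitivity in this test, although no measurement at hand offers any account of that result.

From the compounds shown here alone, what stays open is whether any group at this place can move the number beyond the scatter, for instance an amine, a carboxylic acid or a longer chain, since the three groups compared here form only a narrow set. The trifluoromethyl group is also common to all four compounds, so the compounds shown say nothing about what happens when it is replaced.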